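Swapping a Fluoro for Azetidin-1-yl on the Pyridine Ring

The source may hold more compounds than are shown below. What is called first, only, known or untested is meant among the compounds shown, and "the series" means these compounds.

Of the compounds shown here, three sharing one core have been measured in an in vitro assay on HEK385-7 cells for displacement of a labelled ligand from prostaglandin D2 receptor 2 (Homo sapiens); on this read-out lower numbers stand for stronger inhibition and higher numbers for weaker inhibition. Compound 1, `N#Cc1cc(-c2nc(C(c3ccc(F)cc3)c3ccc(F)cc3)sc2CC(=O)O)ccc1F`, gives 57 nM. Compound 2, `O=C(O)Cc1sc(C(c2ccc(F)cc2)c2ccc(F)cc2)nc1-c1cc(F)cc(F)c1`, gives 35 nM; the change is a 1.6-fold lower number from compound 1 to compound 2 (0.21 log units; within the scatter). Compound 3, `O=C(O)Cc1sc(C(c2ccc(F)cc2)c2ccc(F)cc2)nc1-c1ccnc(F)c1`, gives 0.48 nM, which is the lowest of the three numbers: the steps are a 120-fold lower number from compound 1 to compound 3 (2.07 log units; beyond the scatter) and a 73-fold lower number from compound 2 to compound 3 (1.86 log units; beyond the scatter), both far beyond the scatter, so compound 3 is the most potent of the set. All three steps concern the aromatic ring attached to the core.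

Compound 4, `O=C(O)Cc1sc(C(c2ccc(F)cc2)c2ccc(F)cc2)nc1-c1ccnc(N2CCC2)c1`, keeps the 2-fluoropyridin-4-yl ring of compound 3 but alters it: azetidin-1-yl in place of fluoro on an aromatic carbon. Within the data shown here, none of the measured steps touches this position, since each of them replaced the whole ring rather than a group next to the ring nitrogen, so they give no direct guide to the size or direction of the change. Without such a precedent, the expected step in this assay is a 3.1-fold higher number from compound 3 to compound 4 (0.49 log units; beyond the scatter), modest and uncertain. Compound 4 is therefore estimated at 1.5 nM, with a likely range from 0.3 nM to 8 nM.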

Compound 4, half-maximal inhibitory concentration: 660 nM
Beside the measured number, compound 4's estimate is 440-fold (2.64 log units) below it; measured number above the stated range.
By their numbers in this assay, from the lowest: compound 3; then compounds 2 and 1 (each within the scatter of the next); then compound 4.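

In this assay the group on this one carbon, next to the ring nitrogen, decides the outcome: azetidin-1-yl in place of fluoro gives a 1400-fold higher number from compound 3 to compound 4 (3.14 log units; beyond the scatter) and so removes the whole advantage of compound 3. The 2-(azetidin-1-yl)pyridin-4-yl ring also falls behind both phenyl rings, with a 19-fold higher number from compound 2 to compound 4 (1.28 log units; beyond the scatter) and a 12-fold higher number from compound 1 to compound 4 (1.06 log units; beyond the scatter) showing that a pyridine ring alone does not bring strong inhibition here. Nothing measured in this set explains the size of the loss.

An open-chain dimethylamino group, a plain amino group or a methyl group at this carbon could show whether the loss belongs to amines generally or to the azetidine ring. As far as these compounds go, whether any group other than fluoro keeps inhibition near the level of compound 3 also remains open.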